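The source may report more compounds than this note shows. Statements on the series, on what has been measured and on what is new or still open speak of the compounds shown alone.

Measured in an ADME assay on MCF7 cells (Homo sapiens) for cytotoxicity, with a stated time of 72 h; a higher number here means a weaker inhibitor, a lower number a stronger inhibitor:

compound 1, `Oc1ccccc1CNc1ncnc2c1ncn2C1CCCCO1`, gives > 100000 nM, which is a limit of the assay and not a number.
compound 2, `COc1cccc(CNc2ncnc3c2ncn3C2CCCCO2)c1O`, gives > 100000 nM, again only a limit.
compound 3, `COc1cccc(OC)c1CNc1ncnc2c1ncn2C1CCCCO1`, gives > 100000 nM, again only a limit.

All three measured compounds share one core and differ only in what sits on the aromatic ring of the side group. From compound 1 to compound 2 the change is methoxy in place of hydrogen on an aromatic carbon. The step that the two limits leave unreadable from compound 1 to compound 2 cannot be sized because of the limit of > 100000 nM in this assay, at which 3 of the 3 values shown sit. How the core of compound 3 differs from that of compound 1 is not broken down here.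

Compound 4, `COc1cc(OC)c(CNc2ncnc3c2ncn3C2CCCCO2)c(OC)c1`, is not yet measured. From compound 3 to compound 4 the change is methoxy in place of hydrogen on an aromatic carbon. This is the same kind of change as from compound 1 to compound 2, but the place differs: in compound 2 the entering methoxy stands ortho to a hydroxy group and meta to a large group, whereas in compound 4 it stands meta to two methoxy groups and para to a large group.

Among the compounds with values here, nothing resolves a value: compound 1, compound 2 and compound 3 all rest at the limit of > 100000 nM in this assay, at which 3 of the 3 values shown sit, so the single readable step gives no direction. On that basis the expected step is a step that the limit leaves unreadable from compound 3 to compound 4. Compound 4 is estimated at 150000 nM, with an expected range from 50000 nM to 500000 nM, and is most likely to be reported again only as a limit.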

Compound 4, half-maximal inhibitory concentration: > 50000 nM
Compound 4 ended at the assay's limit (the forecaster's own chance of this, stated with the estimate: 80%); the middle value lies beyond the limit too.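

In this assay compound 4 gives > 50000 nM, which is a limit of the assay and not a number. Compound 3 also stands only at a limit, so no step can be read between compound 3 and compound 4. The compounds shown leave open whether any group on the aromatic ring of the side group gives a readable number in this assay, and in which direction methoxy in place of hydrogen on an aromatic carbon moves the value.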